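This account rests on a few compounds, and the source may have more. Where it says the series, first, only, none or still open, it means among the compounds named here.

This account follows the step from compound 1 `O=S(=O)(NCCNC(=S)Nc1ccc(Cl)cc1)c1ccc(-c2ccccc2OCc2ccccc2)s1` to compound 4 `COc1ccc(NC(=O)NCCNS(=O)(=O)c2ccc(-c3ccccc3OCc3ccccc3)s2)cc1`, which has yet to be measured. Among the measured compounds shown here, in an ADME assay on HEK-293T cells (Homo sapiens) for cytotoxicity, read by CCK-8 assay, with a stated time of 48 h (a higher number here means a weaker inhibitor, a lower number a stronger inhibitor), compound 1 gives 12100 nM, the only plain number among the three compounds measured so far. Compound 2 `COc1ccc(Oc2ccc([N+](=O)[O-])cc2-c2ccsc2S(=O)(=O)N2CCN(C(=O)Nc3ccc([N+](=O)[O-])cc3)CC2)cc1OC` reaches in this assay only a limit, > 20000 nM. Compound 3 `O=[N+]([O-])c1ccc(Oc2ccc(O)c(O)c2)c(-c2ccsc2S(=O)(=O)N2CCN(C(=S)Nc3cc(C(F)(F)F)cc(C(F)(F)F)c3)CC2)c1` likewise ends in this assay at a limit, > 20000 nM. So compound 1 stands alone with a number, while the weight of the set lies at the limit of > 20000 nM in this assay, at which 2 of the 3 values shown sit. Compound 4 differs from compound 1 in one place: a group of 11 heavy atoms (8 carbon, 1 nitrogen, 2 oxygen; one six-membered aromatic ring of carbon only) in place of a group of 10 heavy atoms (7 carbon, 1 nitrogen, 1 sulfur, 1 chlorine; one six-membered aromatic ring of carbon only), on an amine nitrogen. For the measured compounds named here, no measured pair differs in a single place, so no step size can be read from the data. Because compound 1 gives 12100 nM, close to where the other two run out of range, the expected change in this assay is small, towards weaker if any, and likely within the scatter. Compound 4 is expected to give about 18000 nM, within 8000 nM to 40000 nM. The step that this estimate implies, a 1.5-fold higher number from compound 1 to compound 4 (0.17 log units; within the scatter), is expected to stay within the usual scatter.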

Compound 4, half-maximal inhibitory concentration: > 50000 nM
Compound 4 was reported as a limit; the forecaster's own chance of this, stated with the estimate: 45%; middle value at least 2.7-fold (0.44 log units) away from the limit.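

In this assay, among the compounds shown here, this step gives the first reading of a change on this amine nitrogen, which no earlier pair could supply: replacing the group in compound 1 with (4-methoxyphenyl)carbamoyl gives an at least 4.1-fold higher number from compound 1 to compound 4 (0.61 log units; beyond the scatter). The change at this place therefore moves the read-out beyond the scatter, towards a weaker inhibitor. The value of compound 4 is a limit and not a number, so the full size of the step remains unknown: the limit of > 50000 nM in this assay, at which 1 of the 4 values shown sits.

The entering group differs from the leaving one both in the chlorine and sulfur it loses and in the methoxy and carbonyl it gains, and the compounds shown do not separate these parts. On these data alone, how (4-chlorophenyl)carbamoyl, which would keep the chlorine with the carbonyl, would read on this nitrogen remains open.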